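Chloro in place of ethyl on a sulfonamide

The source may hold more compounds than are shown below. What is called first, only, known or untested is meant among the compounds shown, and "the series" means these compounds.

Of the compounds shown here, three sharing one core have been measured in a functional assay on DU-145 cells (Homo sapiens) for inhibition, read by CCK-8 assay, with a stated time of 72 h; a higher number here means a weaker inhibitor, a lower number a stronger inhibitor. Compound 1 `O=C(/C=C/c1cccnc1)NCCCCCCc1cccc(S(=O)(=O)Nc2ccccc2)c1` gives 6.73 nM, compound 2 `Cc1cccc(NS(=O)(=O)c2cccc(CCCCCCNC(=O)/C=C/c3cccnc3)c2)c1` gives 41.7 nM, and compound 3 `CCc1ccc(NS(=O)(=O)c2cccc(CCCCCCNC(=O)/C=C/c3cccnc3)c2)cc1` gives 40.1 nM. Compound 3 therefore cannot be told apart from compound 2, while its number is clearly higher than that of compound 1, which means a weaker inhibitor.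

Compound 4 `O=C(/C=C/c1cccnc1)NCCCCCCc1cccc(S(=O)(=O)Nc2ccc(Cl)cc2)c1` has chloro in place of ethyl on an aromatic carbon, para to a large group: chloro in place of ethyl on an aromatic carbon. Within the data shown here, no chloro compound has been measured yet, so the nearest evidence is indirect. Methyl in place of hydrogen gave a 6.2-fold higher number from compound 1 to compound 2 (0.79 log units; beyond the scatter), and ethyl in place of hydrogen gave a 6.0-fold higher number from compound 1 to compound 3 (0.78 log units; beyond the scatter). These are modest steps of almost the same size. The swap of 3-methylphenyl for 4-ethylphenyl gave a 1.0-fold lower number from compound 2 to compound 3 (0.02 log units; within the scatter), which lies within the scatter. As far as these compounds go, with only these three values, a substituent at this end of the molecule seems to matter more than which one it is, although chloro itself is untested. A small move is therefore expected, with no clear change beyond the scatter. The expected step is a 1.4-fold lower number from compound 3 to compound 4 (0.16 log units; within the scatter). For compound 4 the estimated value in this assay is 28 nM, with an expected range of 10 nM to 70 nM.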

Compound 4, half-maximal inhibitory concentration: 84.4 nM
Estimate against measurement, compound 4: 3.0-fold (0.48 log units) below, and the stated range ends below it.
By their numbers in this assay, from the lowest: compound 1; then compounds 3 and 2 (each within the scatter of the next); then compound 4.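

In this assay, compounds 2 and 3 could not be told apart, which left open whether any added group on this ring had much the same effect, but chloro shows that the choice of group matters: swapping ethyl for chloro gives a 2.1-fold higher number from compound 3 to compound 4 (0.32 log units; beyond the scatter) and swapping 3-methylphenyl for 4-chlorophenyl gives a 2.0-fold higher number from compound 2 to compound 4 (0.31 log units; beyond the scatter) in the same assay, both modest but real steps. Measured against the bare phenyl ring of compound 1, adding chloro gives a 13-fold higher number from compound 1 to compound 4 (1.10 log units; beyond the scatter) and is the only large step of the three from compound 1, and none of the three substituted compounds shown matches compound 1 in this assay. Nothing measured here explains why chloro and ethyl differ at this position.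

Compounds 2 and 3 differ in both the group and where it sits, so a 4-methylphenyl or 3-chlorophenyl ring would be needed to separate those two changes. As far as these compounds go, it also remains open how other groups at this position would behave, such as fluoro, methoxy, an amine or a carboxylic acid, and whether any of them could match the bare phenyl ring.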